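Replacing 3,4-Dichlorophenyl with 4-Methoxyphenyl on an Amide-Type Nitrogen

The compounds below may be only part of what the source reports. "The series", "measured", "known", "first", "only" and "open" are said of these compounds alone.

Compound 1 `COc1ccc(/C=C/C(=O)NO)cc1OCC(=O)Nc1ccc(Br)cc1` with 5870 nM
Compound 2 `COc1ccc(/C=C/C(=O)NO)cc1OCC(=O)Nc1ccc(Cl)c(Cl)c1` with 1900 nM
Compound 3 `COc1ccc(NC(=O)COc2cc(/C=C/C(=O)NO)ccc2OC)cc1` still unmeasured

In a functional assay on MDA-MB-231 cells (Homo sapiens) for inhibition, read by MTT assay, with a stated time of 48 h (on this read-out lower numbers stand for stronger inhibition and higher numbers for weaker inhibition), compound 2 stands lowest of the two numbers, at 1900 nM against the higher figure of compound 1 (5870 nM). Compound 3 carries 4-methoxyphenyl in place of 3,4-dichlorophenyl on an amide-type nitrogen. Going by the values given here, the one measured step at that place (a 3.1-fold lower number from compound 1 to compound 2 (0.49 log units; beyond the scatter)) was modest. Among the compounds with values here, no measured compound carries 4-methoxyphenyl, so this single step is the only guide. A modest step toward a higher number in this assay is therefore expected (a 2.1-fold higher number from compound 2 to compound 3 (0.32 log units; beyond the scatter)). For compound 3 the estimated value is 4000 nM (expected range 1500 nM to 11000 nM).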

Compound 3, half-maximal inhibitory concentration: 3810 nM
The estimate for compound 3 lay 1.0-fold (0.02 log units) above the measured number, and the stated range covers the measured number.
By their numbers in this assay, from the lowest: compounds 2, 3 and 1 (each within the scatter of the next, the first and the last beyond it).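

In this assay, the step of a 2.0-fold higher number from compound 2 to compound 3 (0.30 log units; within the scatter) and the step of a 1.5-fold lower number from compound 1 to compound 3 (0.19 log units; within the scatter) both stay within the scatter, so 4-methoxyphenyl on an amide-type nitrogen cannot be told apart from either halogen-bearing ring. The position therefore accepts a methoxy group without a readable change from either neighbouring compound, and only compound 1 and compound 2 remain separated. No supporting evidence bears on this result. From the compounds shown here alone, whether an amine or a carboxylic acid on this ring, or a cyclohexyl group replacing it, would shift the number beyond the scatter remains open.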